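This account rests on a few compounds, and the source may have more. Where it says the series, first, only, none or still open, it means among the compounds named here.

Measured compounds in a functional assay on A498 cells (Homo sapiens) for inhibition, read by sulforhodamine B assay, with a stated time of 48 h; on this read-out lower numbers stand for stronger inhibition of growth and higher numbers for weaker inhibition of growth:
compound 1 `Cn1cccc1-c1cc(-c2cccs2)nc(N)c1C#N` — > 100000 nM (a limit of the assay, not a number)
compound 2 `Cn1cccc1-c1cc(-c2cccs2)[nH]c(=O)c1C#N` — 17800 nM
compound 3 `Cn1cccc1-c1cc(-c2ccccc2)[nH]c(=O)c1C#N` — 27500 nM

Compound 1 sits at the limit of > 100000 nM in this assay, at which 1 of the 3 values shown sits. The difference between the core of compound 1 and the core of compound 2 is not broken down here. From compound 2 to compound 3 the change is phenyl in place of thiophen-2-yl on an aromatic carbon; the step it made was a 1.5-fold higher number from compound 2 to compound 3 (0.19 log units; within the scatter). Compound 4 `Cn1cccc1-c1cc(-c2ccccc2)nc(N)c1C#N`, not yet measured, arises from compound 1 by phenyl in place of thiophen-2-yl on an aromatic carbon. This is the same kind of change, though in compound 1 the place is meta to an amino group where in compound 2 it is meta to a group of 1 heavy atom. Because the step of a 1.5-fold higher number from compound 2 to compound 3 (0.19 log units; within the scatter) was small, compound 4 is expected to give 150000 nM in this assay, an expected step that the limit leaves unreadable from compound 1 to compound 4, most likely again only a limit.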

Compound 4, concentration for 50% growth inhibition: 91200 nM
Beside the measured number, compound 4's estimate is 1.6-fold (0.22 log units) above it, within the range that was stated.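

In this assay compound 1 gives > 100000 nM and this is a limit of the assay, not a number. On these data alone, putting phenyl in place of thiophen-2-yl on this core gives an at least 1.0-fold lower number from compound 1 to compound 4 (0.04 log units; that floor lies within the scatter) and, with only a floor to read, the true size of this step stays unknown. The change may therefore carry over from one core to the other with a similar effect, but that is not shown: the same change on two cores in this assay, a 1.5-fold higher number (0.19 log units; within the scatter) from compound 2 to compound 3 and an at least 1.0-fold lower number (0.04 log units; that floor lies within the scatter) from compound 1 to compound 4; the limit leaves it open whether they differ.

The compounds shown leave open how either core would respond to other groups on this aromatic carbon, such as a furan-2-yl ring or a phenyl ring carrying a methoxy group or a chlorine atom.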